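Benzylamine aryl variation in a bis(trifluoromethyl)benzenesulfonamide series

A few compounds are considered here, and "the series" means these few. Any claim that something is new, unique, unknown or untested is made for them only; others in the source may bear on it.

Measured so far in a functional assay on MCF7 cells (Homo sapiens) for inhibition, read by MTT assay, with a stated time of 72 h; a lower number here means a stronger inhibitor of growth, a higher number a weaker inhibitor of growth:
- compound 1 `O=S(=O)(NCCCNCc1ccccc1Cl)c1cc(C(F)(F)F)cc(C(F)(F)F)c1` gives 8800 nM
- compound 2 `O=S(=O)(NCCCNCC1COc2ccccc2O1)c1cc(C(F)(F)F)cc(C(F)(F)F)c1` gives 2500 nM
- compound 3 `COc1cccc(CNCCCNS(=O)(=O)c2cc(C(F)(F)F)cc(C(F)(F)F)c2)c1` gives 2400 nM

Compound 1 carries the highest number of the three in this assay; its nearest neighbour is compound 2, and compound 3 lies furthest. Both departures from compound 1 lowered the number: a 3.5-fold lower number from compound 1 to compound 2 (0.55 log units; beyond the scatter) and a 3.7-fold lower number from compound 1 to compound 3 (0.56 log units; beyond the scatter). Compounds 2 and 3 are within the scatter of each other, so no order between them is claimed.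

Compound 4 `O=S(=O)(NCCCNCc1ccc(Cl)cc1)c1cc(C(F)(F)F)cc(C(F)(F)F)c1` differs from compound 1 as 4-chlorophenyl in place of 2-chlorophenyl on a saturated chain carbon bound to an amine nitrogen. Going by the values given here, no measured pair shows this exact change, so the two steps away from compound 1 are only indirect guides; they show that swapping the 2-chlorophenyl for another aryl group has twice given a modestly lower number. A step of similar direction but uncertain size is therefore expected, plausibly a 2.0-fold lower number from compound 1 to compound 4 (0.29 log units; within the scatter). Compound 4 is estimated at 4500 nM in this assay, within a range of 1800 nM to 11000 nM.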

Compound 4, concentration for 50% growth inhibition: 2400 nM
For compound 4 the middle estimate is 1.9-fold (0.27 log units) above the measured one; the measured number falls inside the stated range.
By their numbers in this assay, from the lowest: compounds 3, 4 and 2 (each within the scatter of the next); then compound 1.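

Moving the chlorine alone, with the same atoms joined differently, is enough to give a step on this saturated chain carbon bound to an amine nitrogen: a 3.7-fold lower number from compound 1 to compound 4 (0.56 log units; beyond the scatter) in this assay here, whereas the earlier steps away from compound 1 each brought in a different group. The other two steps, no change at the digits printed from compound 3 to compound 4 (within the scatter) and a 1.0-fold lower number from compound 2 to compound 4 (0.02 log units; within the scatter), leave no order among compound 2, compound 3 and compound 4, so among these four the 2-chlorophenyl of compound 1 alone stands apart. No evidence on hand explains this difference between the two chlorophenyl groups.

Going by these compounds, whether 3-chlorophenyl at this place would give a number like that of compound 1 or like that of compound 4 remains open. Also open, on these data alone, is whether 2-methoxyphenyl would stand apart from the 3-methoxyphenyl of compound 3 as 2-chlorophenyl does from 4-chlorophenyl.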